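Replacing the Hydroxycyclohexyl Group on the Aminopyridine Core

This account rests on a few compounds, and the source may have more. Where it says the series, first, only, none or still open, it means among the compounds named here.

Compound 1 `N#Cc1cnc(NCc2cnccc2C(F)(F)F)cc1N[C@H]1CC[C@@H](O)CC1` is the weaker of the two compounds measured in an assay on isolated protein for inhibition of protein kinase C delta type (Homo sapiens), read by TR-FRET, with a stated time of 2 h; a higher number here means a weaker inhibitor, a lower number a stronger inhibitor: compound 1 gives 4500 nM. Compound 2 `N#Cc1cnc(NCc2ccccc2C(F)(F)F)cc1N[C@H]1CC[C@@H](C(N)=O)CC1`, which differs from it in several places, gives 640 nM in this assay. Compound 3 `CC1(C)[C@@H](Nc2cc(NCc3cnccc3C(F)(F)F)ncc2C#N)C[C@H]1C(N)=O` has not been measured; it alters compound 1 by 3-carbamoyl-2,2-dimethylcyclobutyl in place of 4-hydroxycyclohexyl on a nitrogen on an aromatic ring. With no single-change comparison available, the step is estimated to be a 3.0-fold lower number from compound 1 to compound 3 (0.48 log units; beyond the scatter), a modest lowering of the number. Compound 3 is therefore estimated at 1500 nM, with a range from 400 nM to 5000 nM.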

Compound 3, half-maximal inhibitory concentration: 4500 nM
Compound 3: the middle estimate sits 3.0-fold (0.48 log units) below what was measured, and the stated range covers the measured number.
By their numbers in this assay, from the lowest: compound 2; then compounds 1 and 3 (each within the scatter of the next).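

Among these compounds, this is the first comparison that differs in one place only: on the nitrogen, 3-carbamoyl-2,2-dimethylcyclobutyl in place of 4-hydroxycyclohexyl gives no change at the digits printed from compound 1 to compound 3 (within the scatter) in this assay. On the core of compound 1, then, the four-membered ring with its carbamoyl and two methyl groups reads the same as the six-membered ring with its hydroxyl. No evidence at hand accounts for this result.

Among the compounds shown here, the single step cannot separate the ring size, the methyl groups and the carbamoyl from one another. As far as these compounds go, what an amine or a carboxylic acid on the ring would do at this position also remains open.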